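Hydrazide in place of cyanomethyl amide at the carboxamide

A few compounds are considered here, and "the series" means these few. Any claim that something is new, unique, unknown or untested is made for them only; others in the source may bear on it.

Measured compounds:
Compound 1 `CCOC(=O)c1sc2nc(SC)nc(-c3cccc(OC)c3)c2c1N`, 4.2%
Compound 2 `COc1cccc(-c2nc(SC)nc3sc(C(=O)NCC#N)c(N)c23)c1`, 20.3%
Compound 3 `CSc1nc(-c2cccc(F)c2)c2c(N)c(C(=O)NC(C)(C)C)sc2n1`, 51.1%

In a functional assay on HEK293 cells for agonist activity at lutropin-choriogonadotropic hormone receptor (Homo sapiens), read by cAMP accumulation (on this read-out lower numbers stand for smaller maximal responses and higher numbers for larger maximal responses), compound 2 gives 20.3%, the second highest of the three numbers. Going by the values given here, the nearest is compound 1 with 4.2%; the furthest is compound 3 with 51.1%, which carries a tert-butyl carbamoyl group and a fluorophenyl group and so differs from compound 2 in two places, so no single step links them.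

Compound 4 `COc1cccc(-c2nc(SC)nc3sc(C(=O)NNC(C)(C)C)c(N)c23)c1` is the unmeasured hydrazide. Against compound 2 it shows ((tert-butyl)amino in place of cyanomethyl on an amide-type nitrogen).

Among the compounds with values here, the only measured step, a number 16.1 percentage points higher from compound 1 to compound 2 (beyond the scatter), changed the group on the carbonyl carbon, not the amide-type nitrogen, and so bears only loosely on this change. That compound 3, with a tert-butyl group on its amide nitrogen, reaches 51.1% hints that a bulky saturated group there is compatible with a larger response. A moderate rise is therefore expected, as a number 14.7 percentage points higher from compound 2 to compound 4 (beyond the scatter), with wide uncertainty. Compound 4 is estimated at 35%, between 15% and 60%.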

Compound 4, largest response reached (reported as efficacy), in percent of the reference or control that the assay uses: 6%
The estimate for compound 4 lay 29 percentage points above the measured number, outside the stated range (below it).
By their numbers in this assay, from the lowest: compounds 1 and 4 (each within the scatter of the next); then compound 2; then compound 3.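

In this assay, (tert-butyl)amino in place of cyanomethyl on the amide-type nitrogen gives a number 14.3 percentage points lower from compound 2 to compound 4 (beyond the scatter), which shows that the group on this nitrogen can alter the maximal response and that, of these two groups, cyanomethyl gives the larger one. On the carbonyl carbon, ((tert-butyl)amino)amino and ethoxy cannot be told apart on this read-out, with a number 1.8 percentage points higher from compound 1 to compound 4 (within the scatter). Nothing available explains this step.

The compounds shown leave open whether the inserted amino link or the tert-butyl group accounts for the step, as the core of compound 2 appears here with neither a plain tert-butyl amide nor an unsubstituted hydrazide. They also leave open how a carboxylic acid or a morpholine amide would read at this carbonyl carbon.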